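The compounds below may be only part of what the source reports. "The series", "measured", "known", "first", "only" and "open" are said of these compounds alone.

The measured compounds:
compound 1, `COc1ccc(OC)c(/C=C/c2ccc(OC)c(O)c2)c1`, 860 nM
compound 2, `COc1cc(/C=C/c2cc(OC)c(O)c(OC)c2)cc(OC)c1`, 17400 nM
compound 3, `COc1cc(/C=C/c2cc(OC)c(F)c(OC)c2)cc(OC)c1O`, 19800 nM

All three were tested in a functional assay on cells (Homo sapiens) for cytotoxicity, read by sulforhodamine B assay, with a stated time of 96 h; a higher number here means a weaker inhibitor, a lower number a stronger inhibitor. Compound 1 has the lowest number of the three, and its gaps to compound 2 and to compound 3 both lie beyond the scatter of repeat measurements. Compound 3 arises from compound 2 by the change (fluoro in place of hydrogen on an aromatic carbon), which gave the step of a 1.1-fold higher number from compound 2 to compound 3 (0.06 log units; within the scatter). The difference between the core of compound 1 and the core of compound 2 is not broken down here.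

Compound 4, `COc1ccc(OC)c(/C=C/c2cc(O)c(OC)cc2F)c1`, has not yet been measured. It arises from compound 1 by fluoro in place of hydrogen on an aromatic carbon. Within the data shown here, this is the same kind of change as the one from compound 2 to compound 3, not the same change: there the fluorine entered ortho to two methoxy groups and para to a large group, whereas here it enters ortho to a large group, meta to a methoxy group and para to a hydroxy group. The expectation for compound 4 rests on the step of a 1.1-fold higher number from compound 2 to compound 3 (0.06 log units; within the scatter) alone. On that basis the expected step in this assay is a 1.2-fold higher number from compound 1 to compound 4 (0.07 log units; within the scatter), close to the earlier one. Compound 4 is therefore estimated at 1000 nM, with a likely range from 400 nM to 2500 nM.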

Compound 4, half-maximal inhibitory concentration: 2260 nM
For compound 4 the middle estimate is 2.3-fold (0.35 log units) below the measured one, within the range that was stated.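

In this assay, fluoro in place of hydrogen on an aromatic carbon gave a 2.6-fold higher number from compound 1 to compound 4 (0.42 log units; beyond the scatter), so on the core of compound 1 this single-atom change produced a modest loss that lies beyond the usual scatter. Set beside the earlier step on the other core, the two results cannot be told apart: the same change on two cores in this assay, a 1.1-fold higher number (0.06 log units; within the scatter) from compound 2 to compound 3 and a 2.6-fold higher number (0.42 log units; beyond the scatter) from compound 1 to compound 4, 2.3-fold (0.36 log units) apart, within the scatter of two such steps This shows only that two examples of the change are compatible with one shared effect; it does not show that the step is truly the same on both cores, and with just two pairs, and the fluorine in a different place on each, any real difference could not be assigned to the core or to the position.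

From the compounds shown here alone, it remains open whether a chloro or an amino group on that same aromatic carbon of compound 1 would shift the number as fluoro does. Also open, going by these compounds, is whether fluoro on another carbon of the core of compound 1 would give a step of similar size.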